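The source may hold more compounds than are shown below. What is called first, only, known or untested is meant among the compounds shown, and "the series" means these compounds.

Measured so far in an assay on isolated protein for binding affinity to sphingosine 1-phosphate receptor 2 (Homo sapiens), read by surface plasmon resonance; a lower number here means tighter binding, a higher number weaker binding:
Compound 1 `COc1cc(NC(=O)NNc2cc(-c3ccccc3)c3cnn(C)c3n2)cc(Cl)n1`: 3640 nM
Compound 2 `COc1ccc(-c2cc(NNC(=O)Nc3cc(Br)nc(Br)c3)nc3c2cnn3C)cc1`: 6320 nM

Compound 2 stands alongside compound 1 here: the gap between their two numbers is within the scatter, so the pair cannot be told apart. Compound 3 `COc1ccc(-c2cc(NNC(=O)Nc3cc(Cl)nc(OC)c3)nc3c2cnn3C)cc1` is the next step, with 2-chloro-6-methoxypyridin-4-yl in place of 2,6-dibromopyridin-4-yl on an amide-type nitrogen. The entering group is the same one that compound 1 carries, and compound 1 gives 3640 nM in this assay, close to compound 2. Going by the values given here, no measured pair isolates this change, so the step from compound 2 to compound 3 is expected to be small, a 1.4-fold lower number from compound 2 to compound 3 (0.15 log units; within the scatter), likely not beyond the scatter. Compound 3 is estimated at 4500 nM, with a range from 1500 nM to 13000 nM.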

Compound 3, dissociation constant: 1980 nM
Beside the measured number, compound 3's estimate is 2.3-fold (0.36 log units) above it; low and high end bracket the measured number.
By their numbers in this assay, from the lowest: compounds 3, 1 and 2 (each within the scatter of the next, the first and the last beyond it).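

Going by these compounds alone, on the amide-type nitrogen, 2-chloro-6-methoxypyridin-4-yl in place of 2,6-dibromopyridin-4-yl gives the first step beyond the scatter in this assay (a 3.2-fold lower number from compound 2 to compound 3 (0.50 log units; beyond the scatter)), so binding at this position does respond to a change of group. Methoxy in place of hydrogen on an aromatic carbon, by contrast, stays within the scatter (a 1.8-fold lower number from compound 1 to compound 3 (0.26 log units; within the scatter)). Nothing shown here explains either result.

Which part of the exchange carries the step, the chlorine or the methoxy, stays open. So does how an amine or a carboxylic acid would read on this pyridine ring.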